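Moving the Fluorine on the Benzyl Amide of Compound 1

This account rests on a few compounds, and the source may have more. Where it says the series, first, only, none or still open, it means among the compounds named here.

Measured compounds:
Compound 1, `CN(Cc1cccc(F)c1)C(=O)CCCNC(=O)c1ccc(S(C)(=O)=O)c([N+](=O)[O-])c1`, in an assay on isolated protein for inhibition of thyroid hormone receptor beta (Homo sapiens), read by fluorescence polarization (a lower number here means a stronger inhibitor, a higher number a weaker inhibitor), gives > 60000 nM, which is a limit of the assay.
Compound 2, `CN(Cc1ccccc1F)C(=O)C1CCN(C(=O)c2ccc(S(C)(=O)=O)c([N+](=O)[O-])c2)CC1`, in this assay gives > 60000 nM, also a limit.
Compound 3, `CN(CC(=O)N1CCN(c2ccccc2)CC1)C(=O)c1ccc(S(C)(=O)=O)c([N+](=O)[O-])c1`, in this assay gives > 60000 nM, also a limit.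

Compound 1 therefore stands at the limit of the assay rather than at a measured number, and the same holds for compound 2 and compound 3: the limit of > 60000 nM in this assay, at which 3 of the 3 values shown sit. No pair among these three differs in only one place, so no single step can be read from them; all that can be said is that all three return the same limit.

Compound 4, `CN(Cc1ccccc1F)C(=O)CCCNC(=O)c1ccc(S(C)(=O)=O)c([N+](=O)[O-])c1`, has not been measured in this assay. It differs from compound 1 only in the placement of the fluorine: 2-fluorophenyl in place of 3-fluorophenyl on a saturated chain carbon bound to an amide-type nitrogen, in words 2-fluorophenyl in place of 3-fluorophenyl on a saturated chain carbon bound to an amide-type nitrogen. The same difference, cut one bond further out, reads 3-fluorobenzyl to 2-fluorobenzyl.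

Among the compounds with values here, because compound 1 gives > 60000 nM, a limit, there is no number from which a step could be gauged, and no measured step among the three compounds points in either direction. The expected step from compound 1 to compound 4 is accordingly none beyond the scatter, written as a step that the limit leaves unreadable from compound 1 to compound 4. Compound 4 is estimated at 100000 nM, with a range from 30000 nM to 300000 nM, and most likely the assay will again report only its limit.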

Compound 4, half-maximal inhibitory concentration: > 60000 nM
Compound 4: no number, only a limit; the forecaster's own chance of this, stated with the estimate: 90%; the middle value does not contradict the limit.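

In this assay compound 4 gives > 60000 nM, a limit of the assay. Compound 1 also stands at a limit, so no step can be read between compound 1 and compound 4: the limit of > 60000 nM in this assay, at which 4 of the 4 values shown sit.

The compounds shown leave open whether the placement of the fluorine matters at all, and which structure would give a measurable value.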